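This account rests on a few compounds, and the source may have more. Where it says the series, first, only, none or still open, it means among the compounds named here.

Measured compounds and permeability values:

- compound 1, `COc1ccc(F)cc1CNCCCNc1ccnc2cc(Cc3ccc(C#N)cc3)ccc12`: 23 10^-6 cm/s
- compound 2, `COc1ccc(F)cc1CNCCCNc1ccnc2cc(CC3CCCCC3)ccc12`: 23 10^-6 cm/s
- compound 3, `COc1ccc(F)cc1CNCCCNc1ccnc2cc(CC(C)C)ccc12`: 23 10^-6 cm/s

In an ADME assay for permeability, using PAMPA, with a stated time of 30 min, at pH 7.4 (a higher number here means that the compound crosses the layer faster, a lower number that the compound crosses the layer more slowly), compound 1 gives 23 10^-6 cm/s. In this assay compound 2 gives 23 10^-6 cm/s and compound 3 gives 23 10^-6 cm/s. Compound 3 thus stands level with compounds 1 and 2 at the digits shown; its nearest neighbour is compound 1 and its furthest is compound 2, both within the scatter.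

The three measured steps exchange the group on the saturated chain carbon bound to the aromatic carbon of the shared core: no change at the digits printed from compound 1 to compound 2 (within the scatter), no change at the digits printed from compound 1 to compound 3 (within the scatter) and no change at the digits printed from compound 2 to compound 3 (within the scatter). None of them moved this assay beyond the scatter.

Compound 4, `COc1ccc(F)cc1CNCCCNc1ccnc2cc(-c3cccc4ccccc34)ccc12`, is not yet measured. It differs from compound 3 by naphthalen-1-yl in place of isobutyl on an aromatic carbon. Among the measured compounds shown here, this change is larger than any of the measured steps, since it removes the isobutyl chain and puts two fused six-membered aromatic rings of carbon only directly on the aromatic carbon; no measured pair bears on this exactly. The nearest evidence remains the steps among compounds 1, 2 and 3, which all stayed within the scatter while the group at that part of the core was varied between aryl, cycloalkyl and alkyl.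

On that basis the expected step for compound 4 is a 1.0-fold lower number from compound 3 to compound 4 (0.02 log units; within the scatter), that is no change beyond the scatter. The estimated value for compound 4 in this assay is 22 10^-6 cm/s, with a range from 11 10^-6 cm/s to 40 10^-6 cm/s.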

Compound 4, apparent permeability: 237 10^-6 cm/s
Compound 4: middle estimate off by 11-fold (1.03 log units), on the low side; measured number above the stated range.
By their numbers in this assay, from the lowest: compounds 1, 2 and 3 (each within the scatter of the next); then compound 4.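

The group on the aromatic carbon of the shared core does move the number in this assay: naphthalen-1-yl gives a 10-fold higher number from compound 3 to compound 4 (1.01 log units; beyond the scatter) in place of isobutyl, a 10-fold higher number from compound 2 to compound 4 (1.01 log units; beyond the scatter) in place of cyclohexylmethyl and a 10-fold higher number from compound 1 to compound 4 (1.01 log units; beyond the scatter) in place of 4-cyanobenzyl. Isobutyl, cyclohexylmethyl and 4-cyanobenzyl all put a saturated chain carbon on that aromatic carbon and stay level with one another, whereas compound 4, with two fused six-membered aromatic rings of carbon only bound there directly, stands apart from all three. No measurement shown here accounts for this gap.

Among the compounds shown here, with compound 4 the only member of its kind, the loss of the saturated chain carbon cannot be separated from the entry of the fused aromatic rings; phenyl or naphthalen-2-yl on the same aromatic carbon, and naphthalen-1-ylmethyl there, would divide these two changes. From the compounds shown here alone, whether the higher number survives an amine or a carboxylic acid on the naphthalen-1-yl group also remains open.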